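The source may report more compounds than this note shows. Statements on the series, on what has been measured and on what is new or still open speak of the compounds shown alone.

In a functional assay on MDA-MB-231 cells (Homo sapiens) for antiproliferative activity, read by sulforhodamine B assay (on this read-out higher numbers stand for weaker inhibition of growth and lower numbers for stronger inhibition of growth), compound 2 `CC(C)(C)CCOc1cccc(O)c1C(=O)/C=C/c1ccc(C(=O)O)cc1` gives 11200 nM. Compound 1 `COc1cccc(OCCC(C)(C)C)c1C(=O)/C=C/c1ccc(O)cc1` gives > 30000 nM, which is a limit of the assay and not a number. Compound 3 `O=C(/C=C/c1ccc(O)cc1)c1c(O)cccc1OCC1CCCCC1` gives > 30000 nM, also only a limit, so it stands at the limit of > 30000 nM in this assay, at which 2 of the 3 values shown sit. Compound 4 `CC(C)COc1cccc(O)c1C(=O)/C=C/c1ccc(O)cc1` has isobutoxy in place of the cyclohexylmethoxy of compound 3: isopropyl in place of cyclohexyl on a saturated chain carbon bound to an oxygen on an aromatic ring. Among the compounds with values here, no two measured compounds differ in just one place, so the data show no direct precedent for this change. For compound 4, no step beyond the usual scatter is expected, in either direction, since compound 3 gives > 30000 nM. The estimated change is a number no higher from compound 3 to compound 4 (the limit leaves the size open). Compound 4 is expected to give about 30000 nM, with an estimated range from 14000 nM to 60000 nM.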

Compound 4, concentration for 50% growth inhibition: 3520 nM
The estimate for compound 4 lay 8.5-fold (0.93 log units) above the measured number; measured number below the stated range.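

Within the data shown here, putting isopropyl in place of cyclohexyl on a saturated chain carbon bound to an oxygen on an aromatic ring gives the first readable step at this place: this assay shows an at least 8.5-fold lower number from compound 3 to compound 4 (0.93 log units; beyond the scatter). The group at this place can therefore decide whether growth inhibition appears at all in this series. Compound 3 gives only a limit, so the full size of the step stays open: the limit of > 30000 nM in this assay, at which 2 of the 4 values shown sit.

This single pair cannot separate losing the ring from shortening the group. From the compounds shown here alone, whether a cyclopropyl in the same place would behave like isopropyl or like cyclohexyl remains open.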